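Swapping hydroxy for fluoro in a cytotoxic series

The compounds below may be only part of what the source reports. "The series", "measured", "known", "first", "only" and "open" are said of these compounds alone.

- compound 1 `COC1=C(C)C(=O)/C(=C(O)/C=C/c2ccc(Br)cc2)C(=O)C1(C)C`: 1.7 ug/mL
- compound 2 `COC1=C(C)C(=O)/C(=C(O)/C=C/c2ccc(O)cc2)C(=O)C1(C)C`: 3.8 ug/mL

In a functional assay on KB cells (Homo sapiens) for cytotoxicity (a lower number here means that less compound is needed, a higher number that more compound is needed for the effect), compound 2 gives 3.8 ug/mL, the higher of the two measured numbers, so more of it is needed for the effect. Compound 3 `COC1=C(C)C(=O)/C(=C(O)/C=C/c2ccc(F)cc2)C(=O)C1(C)C` has not yet been measured. It keeps the shared core and changes one group: fluoro in place of hydroxy on an aromatic carbon. Here fluoro replaces hydroxy on an aromatic carbon, para to a large group. For the measured compounds named here, one measured step bears on this change, a swap of bromo for hydroxy on an aromatic carbon: a 2.2-fold higher number from compound 1 to compound 2 (0.35 log units; beyond the scatter). Going by the values given here, compound 3 also lacks the hydroxy, so that modest step suggests a move toward a lower number, although no measurement yet shows how fluoro compares with bromo. The expected change is small, an estimated 1.6-fold lower number from compound 2 to compound 3 (0.20 log units; within the scatter). Compound 3 is expected to give about 2.4 ug/mL, within an estimated range of 1.1 ug/mL to 5 ug/mL.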

Compound 3, concentration for half-maximal effect: 3.7 ug/mL
Compound 3: middle estimate off by 1.5-fold (0.19 log units), on the low side; the measured number falls inside the stated range.
By their numbers in this assay, from the lowest: compound 1; then compounds 3 and 2 (each within the scatter of the next).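

In this assay, hydroxy and fluoro, which differ in their hydrogen-bond donor and acceptor counts, cannot be told apart at this place on the ring (a 1.0-fold lower number from compound 2 to compound 3 (0.01 log units; within the scatter)), so losing the hydroxy does not by itself move the number. Bromo is the group that stands apart, since fluoro in its place also gives a modestly higher number (a 2.2-fold higher number from compound 1 to compound 3 (0.34 log units; beyond the scatter)), and the earlier step to hydroxy had left open whether that rise was specific to hydroxy. Nothing available explains why bromo differs from the other two groups.

Three groups at one place cannot show whether the lower number belongs to bromo alone or extends to a group such as chloro or iodo. On these data alone, how an amine or a carboxylic acid at this place would compare also remains open.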